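A few compounds are considered here, and "the series" means these few. Any claim that something is new, unique, unknown or untested is made for them only; others in the source may bear on it.

Measured in an assay on membranes from HeLa cells for displacement of a labelled ligand from adenosine receptor A3 (Homo sapiens), read by scintillation counting, with a stated time of 180 min, tested at 1 uM; a higher number here means more inhibition at the concentration tested (going by the name of the read-out), a lower number less inhibition:

compound 1, `CCCOC(=O)C1=C(C)NC(=O)NC1c1ccoc1` — 11%
compound 2, `CCCOC(=O)C1=C(C)NC(=O)NC1c1cccs1` — 32%
compound 3, `CCCOC(=O)C1=C(C)NC(=O)NC1c1ccsc1` — 6%

Compound 3 stands lowest of the three numbers in this assay. Its nearest neighbour is compound 1, and the two differ only within the scatter; the gap to compound 2 is larger and real: a number 26 percentage points lower from compound 2 to compound 3 (beyond the scatter). The three measured steps all concern the group on the saturated ring carbon. One of them, the step from compound 2 to compound 3, is already given; the other two are a number 21 percentage points higher from compound 1 to compound 2 (beyond the scatter) and a number 5 percentage points lower from compound 1 to compound 3 (within the scatter).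

Compound 4, `CC1=C(C(=O)NC(C)C)C(c2ccsc2)NC(=O)N1`, keeps the thiophen-3-yl of compound 3 and changes the other end: isopropylamino in place of propoxy on a carbonyl carbon. Among the compounds with values here, none of the measured steps touches this carbonyl carbon, so no step bears directly on the change, and the series gives no basis to expect a move beyond the scatter in either direction in this assay. The starting point is low, which limits how far a number can fall.

Compound 4 is therefore expected near 10%, with a range from 0% to 30%. The expected step is a number 4 percentage points higher from compound 3 to compound 4 (within the scatter), which lies within the scatter.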

Compound 4, a percentage reported as inhibition, at one concentration (the size of the read-out at that concentration, not a potency): 1%
Compound 4: middle estimate off by 9 percentage points, on the high side; low and high end bracket the measured number.
By their numbers in this assay, from the lowest: compounds 4, 3 and 1 (each within the scatter of the next); then compound 2.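

In this assay, within the data shown here, a number 5 percentage points lower from compound 3 to compound 4 (within the scatter), the first reading of any change on the carbonyl carbon, where earlier steps concerned only the group on the saturated ring carbon. Exchanging propoxycarbonyl for isopropylcarbamoyl swaps a hydrogen-bond acceptor for a hydrogen-bond donor in the counted groups at equal heavy-atom count, yet it gives no change beyond the scatter in this thiophen-3-yl setting, although compound 3 at 6% already leaves little room for any fall to show. No measurement available here bears on why the number stays where it does.

The compounds shown leave open whether isopropylamino would have a readable effect with the thiophen-2-yl group, where compound 2 at 32% offers more room for a fall in this assay. Also open, from the compounds shown here alone, is how other groups on the carbonyl carbon would read with either thiophene, for instance a longer chain such as butoxy, a cyclic amine such as piperidine, or a free carboxylic acid.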